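This account rests on a few compounds, and the source may have more. Where it says the series, first, only, none or still open, it means among the compounds named here.

Compound 1, `CN1CCC(C(=O)Nc2n[nH]c3c2CN(C(=O)C(C)(C)C)C3(C)C)CC1`, is tested in a functional assay on A2780 cells (Homo sapiens) for antiproliferative activity, read by fluorescence, with a stated time of 72 h (a higher number here means a weaker inhibitor, a lower number a stronger inhibitor), where compound 1 gives 350 nM. Among the two plain numbers shown, compound 1 holds the lowest, though its nearest neighbour compound 3, `CN1CCC(C(=O)N2Cc3c(NC(=O)c4ccncc4)n[nH]c3C2(C)C)CC1`, gives 500 nM in this assay, a gap that lies within the scatter. Compound 2, `CN1CCC(C(=O)N2Cc3c(NC(=O)c4ccco4)n[nH]c3C2(C)C)CC1`, reaches only a limit in this assay, reported as > 5000 nM. Evidence of that limit is the limit of > 5000 nM in this assay, at which 1 of the 3 values shown sits. The change on the carbonyl carbon that carries the amide-type nitrogen gives an at least 10-fold lower number from compound 2 to compound 3 (1.00 log units; beyond the scatter), so the group on that carbonyl plainly matters.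

Compound 4, `CC(C)(C)C(=O)N1Cc2c(NC(=O)c3ccc(F)cc3)n[nH]c2C1(C)C`, has not yet been measured. The change from compound 1 to compound 4 is 4-fluorophenyl in place of 1-methylpiperidin-4-yl on a carbonyl carbon. Among the compounds with values here, the only measured step at a carbonyl of this kind is the one from compound 2 to compound 3, which compared two aromatic rings rather than a saturated ring against an aromatic one, so it shows that the result can move well beyond the scatter without fixing the direction here. Compound 4 is therefore expected to land at 500 nM, within 120 nM to 2500 nM, an expected step of a 1.4-fold higher number from compound 1 to compound 4 (0.15 log units; within the scatter).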

Compound 4, half-maximal inhibitory concentration: 270 nM
Compound 4: the middle estimate sits 1.9-fold (0.27 log units) above what was measured; the measured number falls inside the stated range.
By their numbers in this assay, from the lowest: compounds 4, 1 and 3 (each within the scatter of the next). At a limit, above all of these: compound 2.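

On the carbonyl carbon whose other neighbour is the amide-type nitrogen, a saturated ring can give way to an aromatic one with little consequence in this assay: the exchange gives a 1.3-fold lower number from compound 1 to compound 4 (0.11 log units; within the scatter) and so does not separate the two groups. A ring nitrogen in this group is therefore not needed for activity in this range, as the 4-fluorophenyl ring of compound 4 holds only carbon atoms, with fluorine as its substituent. Nothing shown here explains why the two groups perform so alike.

On these data alone, what the fluorine itself contributes stays open, as a plain phenyl ring would be needed to isolate it. It is also unclear how far this tolerance extends on the same carbonyl, for instance to a short open chain ending in an amine or to a group carrying a carboxylic acid.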